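Swapping the Ortho Substituent: From Vinyloxy to Formyl

This account rests on a few compounds, and the source may have more. Where it says the series, first, only, none or still open, it means among the compounds named here.

Compound 1 `CCc1ccccc1OC(C)C1=NCCN1`: 100 nM
Compound 2 `C=COc1ccccc1OC(C)C1=NCCN1`: 631 nM

In a functional assay on CHO cells for agonist activity at Alpha-2C adrenergic receptor (Homo sapiens) (on this read-out higher numbers stand for an effect only at larger amounts of compound and lower numbers for an effect already at smaller amounts), compound 2 gives the higher of the two numbers, and the step of a 6.3-fold higher number from compound 1 to compound 2 (0.80 log units; beyond the scatter) shows how far it sits above compound 1. Compound 3 `CC(Oc1ccccc1C=O)C1=NCCN1` carries formyl in place of vinyloxy on an aromatic carbon. For the measured compounds named here, no measured step exchanges vinyloxy for formyl, so the only guidance is that the single change at this position moved the number beyond the scatter. A modest shift is therefore expected, in either direction, with a 1.6-fold lower number from compound 2 to compound 3 (0.20 log units; within the scatter) as the estimate. Compound 3 is expected to give about 400 nM, between 100 nM and 1600 nM.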

Compound 3, half-maximal effective concentration: 100 nM
Compound 3: middle estimate off by 4.0-fold (0.60 log units), on the high side; low and high end bracket the measured number.
By their numbers in this assay, from the lowest: compounds 1 and 3 (each within the scatter of the next); then compound 2.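

In this assay, formyl in place of vinyloxy gives a 6.3-fold lower number from compound 2 to compound 3 (0.80 log units; beyond the scatter) and so reverses the rise seen earlier, showing that the number at this position can move down as well as up. Formyl in place of ethyl gives no change at the digits printed from compound 1 to compound 3 (within the scatter) and so leaves these two groups indistinguishable here, with vinyloxy alone standing apart. No measurement at hand gives a reason for these shifts. Still open, from the compounds shown here alone, is whether an amine, a carboxylic acid or a longer chain on this aromatic carbon would match compound 1 and compound 3 or compound 2.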